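Swapping a phenol for a bromoindole on a shared core

This account rests on a few compounds, and the source may have more. Where it says the series, first, only, none or still open, it means among the compounds named here.

Compound 3 `Cc1ccc(CS/C(=C/c2ccc(O)cc2)C(=O)c2ccc(Cl)cc2)cc1` was tested in a functional assay on DU-145 cells (Homo sapiens) for inhibition, read by trypan blue exclusion, with a stated time of 96 h (on this read-out lower numbers stand for stronger inhibition of growth and higher numbers for weaker inhibition of growth), where compound 3 gives 10000 nM. Compound 1 `COc1ccccc1/C=C(/SCc1ccc(C)cc1)C(=O)c1ccc(Cl)cc1` gives 10000 nM in this assay, and compound 2 `O=C(/C(=C\c1c[nH]c2ccc(Br)cc12)SCc1ccc(Cl)cc1Cl)c1ccc(Cl)cc1` gives 10000 nM. Compound 3 stands level with both on the numbers shown: the one step that joins two measured compounds, no change at the digits printed from compound 1 to compound 3 (within the scatter), lies within the scatter, and the gap between compound 3 and compound 2 is likewise no change at the digits given. Compound 4 `Cc1ccc(CS/C(=C/c2c[nH]c3ccc(Br)cc23)C(=O)c2ccc(Cl)cc2)cc1` differs from compound 3 in one place: 5-bromo-1H-indol-3-yl in place of 4-hydroxyphenyl on a double-bonded chain carbon bound to a double-bonded chain carbon. For the measured compounds named here, no measured step swaps these two groups directly, so the only guides are the unchanged step between compound 1 and compound 3 and the fact that compound 2, which carries the 5-bromo-1H-indol-3-yl group on the same place, sits at the same level as the others. Taken together, the expected step is no change at the digits printed from compound 3 to compound 4 (within the scatter), none beyond the scatter. Compound 4 is therefore estimated at 10000 nM, with a range from 5000 nM to 20000 nM.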

Compound 4, concentration for 50% growth inhibition: 1000 nM
For compound 4 the middle estimate is 10-fold (1.00 log units) above the measured one, and the stated range ends above it.
By their numbers in this assay, from the lowest: compound 4; then compounds 1, 2 and 3 (each within the scatter of the next).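

In this assay the 5-bromo-1H-indol-3-yl group stands apart from both groups it replaces on the double-bonded chain carbon when the 4-methylphenyl group is kept (a 10-fold lower number from compound 3 to compound 4 (1.00 log units; beyond the scatter); a 10-fold lower number from compound 1 to compound 4 (1.00 log units; beyond the scatter)). The indole group does not bring this lower number by itself: compound 2 also carries it, and the drop appears only with 4-methylphenyl in place of 2,4-dichlorophenyl on a saturated chain carbon bound to a sulfur (a 10-fold lower number from compound 2 to compound 4 (1.00 log units; beyond the scatter)), so in these compounds the effect of one place depends on the group at the other. No supporting measurement is available to explain this result.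

The compounds shown do not separate the part played by the bromine from that of the indole rings, which an unsubstituted 1H-indol-3-yl or a 5-chloro-1H-indol-3-yl group would address. On these data alone, how an amine or a longer chain would fare at either place also stays open.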